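The source may hold more compounds than are shown below. What is called first, only, known or untested is meant among the compounds shown, and "the series" means these compounds.

Compound 1 `NC[C@@H]1CCCc2cc(S(=O)(=O)c3cc[nH]c3)ccc21` gives 0.316 nM
Compound 2 `NC[C@@H]1CCCc2cc(S(=O)(=O)c3cc(F)cc4[nH]cnc34)ccc21` gives 5.01 nM
Compound 3 `NC(=O)CNC[C@@H]1CCCc2cc(S(=O)(=O)c3cccc(F)c3)ccc21` gives 0.1 nM

In an assay on isolated protein for displacement of a labelled ligand from 5-hydroxytryptamine receptor 6 (Homo sapiens) (on this read-out lower numbers stand for stronger inhibition and higher numbers for weaker inhibition), compound 3 stands lowest of the three numbers shown; compound 1 is nearest, and compound 2 is furthest, both beyond the scatter. Compound 4 `CN(C)C(=O)NC[C@@H]1CCCc2cc(S(=O)(=O)c3cccc(F)c3)ccc21` is the next step. The change is dimethylcarbamoyl in place of carbamoylmethyl on an amine nitrogen whose other neighbour is a saturated chain carbon. Within the data shown here, no comparable step between measured compounds is available, so the size of the step is an open question. Compound 4 is expected to give 0.3 nM (range 0.08 nM to 1.2 nM), that is a step of a 3.0-fold higher number from compound 3 to compound 4 (0.48 log units; beyond the scatter), a modest loss that may yet fall within the scatter of compound 3 at 0.1 nM.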

Compound 4, inhibition constant: 2.51 nM
Estimate against measurement, compound 4: 8.4-fold (0.92 log units) below; measured number above the stated range.
By their numbers in this assay, from the lowest: compound 3; then compound 1; then compounds 4 and 2 (each within the scatter of the next).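

In this assay dimethylcarbamoyl in place of carbamoylmethyl on this amine nitrogen gives a 25-fold higher number from compound 3 to compound 4 (1.40 log units; beyond the scatter) and so provides the first matched comparison, showing that this position is sensitive to the group it carries. The entering group has no hydrogen-bond donor where the leaving one has one, and it has one more heavy atom. Nothing shown explains the size of this step.

The compounds shown do not separate the roles of the two methyl groups and the changed chain. An unsubstituted urea or an acetyl group on the same nitrogen would remain to be compared.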